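This account rests on a few compounds, and the source may have more. Where it says the series, first, only, none or still open, it means among the compounds named here.

Compound 1 `COc1ccc(-n2ncnc2-c2cc(OC)c(OC)c(OC)c2)cc1` is tested in a functional assay on HL-60 cells (Homo sapiens) for antiproliferative activity, read by MTT assay, with a stated time of 72 h (on this read-out higher numbers stand for weaker inhibition and lower numbers for stronger inhibition), where compound 1 gives 6200 nM. Of the two plain numbers measured here this is the highest; compound 3 `COc1cc(-n2ncnc2-c2ccc(SC)cc2)cc(OC)c1OC` gives 500 nM. Compound 2 `COc1cc(-c2ncnn2-c2ccc([N+](=O)[O-])cc2)cc(OC)c1OC` gives only a limit of the assay, > 10000 nM. The step of an at least 1.6-fold higher number from compound 1 to compound 2 (0.20 log units; that floor lies within the scatter) is bounded by the limit of > 10000 nM in this assay, at which 1 of the 3 values shown sits. Compound 4 `COc1cc(-c2ncnn2-c2cccc(F)c2)cc(OC)c1OC` differs from compound 1 in one place: 3-fluorophenyl in place of 4-methoxyphenyl on an aromatic nitrogen. For the measured compounds named here, the only measured step that touches the phenyl group on the aromatic nitrogen is an at least 1.6-fold higher number from compound 1 to compound 2 (0.20 log units; that floor lies within the scatter), and its floor stays within the scatter, so for compound 4 a step no larger than the scatter is expected, a 1.0-fold lower number from compound 1 to compound 4 (0.01 log units; within the scatter). Compound 4 is therefore estimated at 6000 nM, with a range from 2000 nM to 18000 nM.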

Compound 4, half-maximal inhibitory concentration: > 10000 nM
Compound 4 gave a limit, no number; the forecaster's own chance of this, stated with the estimate: 25%; middle value at least 1.6-fold (0.22 log units) from the limit.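

In this assay the value of compound 4 is a limit, not a number. The change to 3-fluorophenyl on the aromatic nitrogen can therefore be read only as a floor, and that floor does not clear the usual scatter: an at least 1.6-fold higher number from compound 1 to compound 4 (0.20 log units; that floor lies within the scatter). Together with compound 2, this makes a second replacement of the 4-methoxyphenyl group that ends at a limit rather than a value: the limit of > 10000 nM in this assay, at which 2 of the 4 values shown sit.

As far as these compounds go, how far compound 2 and compound 4 lie past that limit stays open, so no order between them can be given. Also open, from the compounds shown here alone, is how a phenyl group carrying an amine or a carboxylic acid would read at this position.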